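One group exchanged between compound 1 and compound 4

The source may report more compounds than this note shows. Statements on the series, on what has been measured and on what is new or still open speak of the compounds shown alone.

- compound 1 `CC1(C)OCC(Cn2cc(Cn3c4c(c5ccccc53)C(=O)c3c[n+]([O-])c5ccccc5c3C4=O)nn2)O1`: 5510 nM
- compound 2 `O=C1c2c[n+]([O-])c3ccccc3c2C(=O)c2c1c1ccccc1n2CCCCN1CCNCC1`: 760 nM
- compound 3 `CN(C)CCCCn1c2c(c3ccccc31)C(=O)c1c[n+]([O-])c3ccccc3c1C2=O`: 520 nM

In a toxicity assay on HEK-293T cells (Homo sapiens) for cytotoxicity, read by MTT assay, with a stated time of 72 h (on this read-out lower numbers stand for stronger inhibition and higher numbers for weaker inhibition), compound 1 gives 5510 nM, the highest number of the three and so the weakest inhibition seen here. Compound 2 gives 760 nM and compound 3 gives 520 nM, both clearly lower numbers than that of compound 1.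

The next structure is compound 4 `O=C1c2c[n+]([O-])c3ccccc3c2C(=O)c2c1c1ccccc1n2Cc1cn([C@@H]2O[C@H](CO)[C@@H](O)[C@H](O)[C@H]2O)nn1`. It keeps the core of compound 1 and exchanges one group: 3,4,5-trihydroxy-6-(hydroxymethyl)oxan-2-yl in place of (2,2-dimethyl-1,3-dioxolan-4-yl)methyl on an aromatic nitrogen. In words, 3,4,5-trihydroxy-6-(hydroxymethyl)oxan-2-yl stands in place of (2,2-dimethyl-1,3-dioxolan-4-yl)methyl on an aromatic nitrogen of a five-membered aromatic ring with 3 nitrogen.

Among the measured compounds shown here, only one measured step is available, a 1.5-fold lower number from compound 2 to compound 3 (0.16 log units; within the scatter). It lies within the scatter and concerns dimethylamino in place of piperazin-1-yl on a saturated chain carbon, which is a different change at a different place. It therefore gives no guide to the size or direction of this exchange, and the best anchor is compound 1 at 5510 nM.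

The expected result in this assay is a 1.1-fold lower number from compound 1 to compound 4 (0.04 log units; within the scatter), which means no change beyond the scatter. Compound 4 is estimated at 5000 nM, with an expected range from 1500 nM to 20000 nM.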

Compound 4, half-maximal inhibitory concentration: 940 nM
For compound 4 the middle estimate is 5.3-fold (0.73 log units) above the measured one; the whole stated range lies above it.
By their numbers in this assay, from the lowest: compounds 3, 2 and 4 (each within the scatter of the next); then compound 1.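

In this assay, among the compounds shown here, the group on an aromatic nitrogen of the five-membered aromatic ring with 3 nitrogen proves able to shift the result: putting 3,4,5-trihydroxy-6-(hydroxymethyl)oxan-2-yl in place of (2,2-dimethyl-1,3-dioxolan-4-yl)methyl gives a 5.9-fold lower number from compound 1 to compound 4 (0.77 log units; beyond the scatter) and so moves the number beyond the scatter, unlike the only earlier step, which concerned a different place and stayed within it. The exchange alters several counted features at once, going from 8 to 11 heavy atoms, from 0 to 4 hydrogen-bond donors and from 2 to 5 hydrogen-bond acceptors, and adding 5 defined stereocentres, so this single step cannot assign the shift to any one of them. No measurement is available here to explain the shift.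

The compounds shown leave open which of these features matters and whether the arrangement of the 5 defined stereocentres plays any part. They also leave open how a much smaller group on the same nitrogen, such as a 2-hydroxyethyl chain, or a group bearing a carboxylic acid would compare with 3,4,5-trihydroxy-6-(hydroxymethyl)oxan-2-yl.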